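The source may report more compounds than this note shows. Statements on the series, on what has been measured and on what is new or still open speak of the compounds shown alone.

Compound 1 `CCCSc1nnc(Cc2ccccc2Oc2ccccc2)[nH]1` carries a propyl chain on the sulfur of the shared core, and in a functional assay on the whole organism (strain NMRI) with Mus musculus as the target, with a stated time of 60 min, at a dose of 5 mg/kg by the intraperitoneal route (on this read-out lower numbers stand for a weaker effect and higher numbers for a stronger effect at the one dose given), compound 1 gives 128%. Compound 2 `c1ccc(CSc2nnc(Cc3ccccc3Oc3ccccc3)[nH]2)cc1` differs from it by phenyl in place of ethyl on a saturated chain carbon bound to a sulfur, and in this assay compound 2 gives 129%; the change made a number 1 percentage points higher from compound 1 to compound 2 (within the scatter). Compound 3 `CCCSc1nnc(Cc2ccc(Cl)cc2Oc2ccccc2Cl)[nH]1` has a core that is not the same as that of compound 1, and the difference between the two cores is not broken down here. In this assay compound 3 gives 118%; its value and that of compound 1 lie within the scatter of each other, while compound 2 stands beyond the scatter above compound 3.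

Compound 4 `Clc1ccc(Cc2nnc(SCc3ccccc3)[nH]2)c(Oc2ccccc2Cl)c1` is derived from compound 3 by phenyl in place of ethyl on a saturated chain carbon bound to a sulfur, the same change that led from compound 1 to compound 2, at the same place. Since that change made a number 1 percentage points higher from compound 1 to compound 2 (within the scatter), the step from compound 3 to compound 4 in this assay is expected to be similarly small, about a number 1 percentage points higher from compound 3 to compound 4 (within the scatter). Compound 4 is therefore estimated to give around 119%, most likely between 104% and 134%.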

Compound 4, a percentage reported as activity, at one dose (the size of the read-out at that dose, not a potency): 113%
Estimate against measurement, compound 4: 6 percentage points above; low and high end bracket the measured number.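

On the core of compound 3, phenyl in place of ethyl on a saturated chain carbon bound to a sulfur gave a number 5 percentage points lower from compound 3 to compound 4 (within the scatter) in this assay. Set beside the earlier step, the change behaves no differently on the two cores: the same change on two cores in this assay, a number 1 percentage points higher (within the scatter) from compound 1 to compound 2 and a number 5 percentage points lower (within the scatter) from compound 3 to compound 4, 6 percentage points apart, within the scatter of two such steps. This shows that, on these two cores, the swap from propyl to benzyl on the sulfur leaves the read-out within the scatter, but it does not show that the same would hold on any other core, and a read-out at a single dose says nothing about potency.

The compounds shown leave open how a longer chain, a chain ending in an amine or one ending in a carboxylic acid would read on the sulfur in this assay. From the compounds shown here alone, it also remains open whether the small size of the step would persist on a core carrying fluorine in place of chlorine.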